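The source may hold more compounds than are shown below. What is called first, only, known or untested is meant among the compounds shown, and "the series" means these compounds.

Compound 1 `Oc1ccc(C(c2c[nH]c3ccc(Br)cc23)c2c[nH]c3ccc(Br)cc23)cc1`: 3500 nM
Compound 2 `Brc1ccc2[nH]cc(C(c3c[nH]c4ccc(Br)cc34)C3CCCCC3)c2c1`: 4100 nM

In a functional assay on MCF7 cells (Homo sapiens) for inhibition, read by MTT assay, with a stated time of 48 h (on this read-out lower numbers stand for stronger inhibition and higher numbers for weaker inhibition), compound 2 gives 4100 nM, which lies within the usual scatter of compound 1 at 3500 nM. The two cannot be told apart on these numbers.

Compound 3 `CCCCCCCC(c1c[nH]c2ccc(Br)cc12)c1c[nH]c2ccc(Br)cc12` has not yet been measured. It carries heptyl in place of cyclohexyl on a saturated chain carbon bound to two aromatic carbons.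

For the measured compounds named here, only one measured step bears on this change. It swaps the group on that same carbon, and it amounts to a 1.2-fold higher number from compound 1 to compound 2 (0.07 log units; within the scatter). That single step gives no sign of a real shift in this assay, so no step beyond the scatter is expected. Going by the values given here, no measured compound has an open chain at this carbon, which keeps the range wide.

The expected change is a 1.0-fold lower number from compound 2 to compound 3 (0.01 log units; within the scatter). Compound 3 is estimated at 4000 nM, with an expected range of 1600 nM to 10000 nM.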

Compound 3, half-maximal inhibitory concentration: 5500 nM
Estimate against measurement, compound 3: 1.4-fold (0.14 log units) below; the measured number falls inside the stated range.
By their numbers in this assay, from the lowest: compounds 1, 2 and 3 (each within the scatter of the next).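

In this assay an open chain at this saturated carbon bound to two aromatic carbons can now be set against two rings: heptyl gives a 1.3-fold higher number from compound 2 to compound 3 (0.13 log units; within the scatter) when it replaces cyclohexyl, and a 1.6-fold higher number from compound 1 to compound 3 (0.20 log units; within the scatter) when it replaces 4-hydroxyphenyl. Both steps lie within the scatter, so these three groups cannot be told apart here, and giving up the ring at this carbon brings no measurable loss or gain in this read-out. Nothing available explains this result.

The compounds shown leave open whether any group at this carbon can move the number beyond the scatter. An amine or a carboxylic acid at the end of the chain, or a chain much longer than heptyl, would test this.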